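A few compounds are considered here, and "the series" means these few. Any claim that something is new, unique, unknown or untested is made for them only; others in the source may bear on it.

Measured compounds:
compound 1 `CCCCCCCCn1cc(/C=C/C(=O)c2ccc(NC(=O)CN3CCN(c4ccccc4F)CC3)cc2)nn1` — 68600 nM
compound 2 `O=C(CN1CCN(c2ccccc2F)CC1)Nc1ccc(C(=O)/C=C/c2cn(Cc3ccc(Br)cc3)nn2)cc1` — 11300 nM

In a functional assay on MCF7 cells (Homo sapiens) for inhibition, read by MTT assay (a lower number here means a stronger inhibitor, a higher number a weaker inhibitor), compound 1 gives 68600 nM, the higher of the two numbers; compound 2 gives 11300 nM. Within the data shown here, the one measured step, a 6.1-fold lower number from compound 1 to compound 2 (0.78 log units; beyond the scatter), concerns the chain carbon bound to the aromatic nitrogen, where 4-bromophenyl replaces heptyl, and it is the only change so far that moves the number beyond the scatter.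

Compound 3 `CCCCCCCCn1cc(/C=C/C(=O)c2ccc(NC(=O)CN3CCN(c4ccccc4OC)CC3)cc2)nn1` keeps the heptyl end of compound 1 and differs from it only at the other end: methoxy in place of fluoro on an aromatic carbon. Among the measured compounds shown here, no measured step touches the 2-fluorophenyl end, so the step from compound 1 to compound 2 does not bear on this change and offers no guide to its direction. With nothing in the series to support a shift of the size seen there, the expected step from compound 1 to compound 3, a 1.1-fold lower number from compound 1 to compound 3 (0.06 log units; within the scatter), is small and within the scatter. Compound 3 is therefore expected to give about 60000 nM in this assay, with a range from 20000 nM to 180000 nM.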

Compound 3, half-maximal inhibitory concentration: 30000 nM
Compound 3: middle estimate off by 2.0-fold (0.30 log units), on the high side; the measured number falls inside the stated range.
By their numbers in this assay, from the lowest: compound 2; then compound 3; then compound 1.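

In this assay, among these compounds, the change from 2-fluorophenyl to 2-methoxyphenyl gives a 2.3-fold lower number from compound 1 to compound 3 (0.36 log units; beyond the scatter), the first reading at this end of the molecule. Among the compounds shown here, the number therefore responds to a substituent on this aromatic carbon, ortho to a large group, and not only to the group on the chain carbon at the other end, where the only earlier step was a 6.1-fold lower number from compound 1 to compound 2 (0.78 log units; beyond the scatter). Both steps from compound 1 lie beyond the scatter and lower the number, but no measurement available here accounts for the effect of exchanging fluoro for methoxy.

From the compounds shown here alone, the methoxy change is read only with the heptyl end in place, so it remains open whether it would lower the number to a similar extent with the 4-bromophenyl end of compound 2. Also open, going by these compounds, is how this aromatic carbon would respond to other groups, such as chloro, hydroxyl or an amine, and thus whether the step reflects something specific to methoxy or a more general departure from fluoro.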